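Acylhydrazide for thiazolyl on the amide nitrogen: cytotoxicity outlook

The source may report more compounds than this note shows. Statements on the series, on what has been measured and on what is new or still open speak of the compounds shown alone.

Compound 2 `COc1ccc2nc(C)cc(OCC(=O)Nc3nccs3)c2c1` stands at the ceiling of a toxicity assay on HepG2 cells (Homo sapiens) for inhibition, read by CellTiter-Glo, with a stated time of 48 h; on this read-out higher numbers stand for weaker inhibition and lower numbers for stronger inhibition: in this assay compound 2 gives > 100000 nM, a limit rather than a number. Compound 1 `COc1ccc2nc(C)cc(OCC(=O)Nc3ccccn3)c2c1` likewise gives only a limit, > 100000 nM. The step that the two limits leave unreadable from compound 1 to compound 2 is thus unreadable, both values sitting at the limit (the limit of > 100000 nM in this assay, at which 2 of the 2 values shown sit). Compound 3 `COc1ccc2nc(C)cc(OCC(=O)NNC(=O)c3ccncc3)c2c1` differs from compound 2 by ((pyridin-4-yl)carbonyl)amino in place of 1,3-thiazol-2-yl on an amide-type nitrogen. No readable step bears on this change, so no shift beyond the scatter is expected. The expected step is a step that the limit leaves unreadable from compound 2 to compound 3. Compound 3 is estimated at 150000 nM, within 50000 nM to 500000 nM, most probably reported again as a limit.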

Compound 3, half-maximal inhibitory concentration: > 100000 nM
Compound 3: a limit, no number; the forecaster's own chance of this, stated with the estimate: 80%; the middle value lies beyond the limit too.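

Among the compounds shown here, no step among compound 1, compound 2 and compound 3 can be read, as all three values are limits: the limit of > 100000 nM in this assay, at which 3 of the 3 values shown sit. The compounds shown leave open whether pyridin-2-yl, 1,3-thiazol-2-yl and ((pyridin-4-yl)carbonyl)amino differ at all in this assay.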